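Aryl exchange on the nitrogen-rich five-membered ring: compound 4

The compounds below may be only part of what the source reports. "The series", "measured", "known", "first", "only" and "open" are said of these compounds alone.

Measured so far in a functional assay on HCT-116 cells (Homo sapiens) for antiproliferative activity, read by MTT assay, with a stated time of 48 h; a lower number here means a stronger inhibitor, a higher number a weaker inhibitor:
Compound 1 `CCOc1ccccc1-n1nncc1CN1C(=O)C2(C(C#N)=C(N)Oc3c2c2nc4ccccc4nc2c2ccccc32)c2ccccc21` gives > 50000 nM, which is a limit of the assay rather than a number.
Compound 2 `N#CC1=C(N)Oc2c(c3nc4ccccc4nc3c3ccccc23)C12C(=O)N(Cc1cnnn1-c1ccc([N+](=O)[O-])cc1)c1ccccc12` gives > 50000 nM, again only a limit.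
Compound 3 `Cc1ccc(-n2nncc2CN2C(=O)C3(C(C#N)=C(N)Oc4c3c3nc5ccccc5nc3c3ccccc43)c3ccccc32)cc1Cl` gives > 50000 nM, also a limit.

Compound 2 thus stands at the ceiling of what this assay reports, and nothing separates it from the other two: all three values sit at the limit of > 50000 nM in this assay, at which 3 of the 3 values shown sit. For that reason every step between the measured compounds is unreadable: a step that the two limits leave unreadable from compound 1 to compound 2, a step that the two limits leave unreadable from compound 1 to compound 3 and a step that the two limits leave unreadable from compound 2 to compound 3. Compound 4 `Cc1ccc(Cl)cc1-n1nncc1CN1C(=O)C2(C(C#N)=C(N)Oc3c2c2nc4ccccc4nc2c2ccccc32)c2ccccc21` changes the aryl group on the aromatic nitrogen: 5-chloro-2-methylphenyl in place of 4-nitrophenyl on an aromatic nitrogen. Among the compounds with values here, the steps that bear on this change are the three just named, none of which has a readable size, so no direction can be drawn from them. Compound 3, which carries a chloro-methylphenyl isomer at the same position, also reaches only the limit. The expected step is therefore a step that the limit leaves unreadable from compound 2 to compound 4, nothing readable beyond the limit. Compound 4 is accordingly estimated at 80000 nM, in the range 30000 nM to 250000 nM, and most probably this assay will again report only a limit.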

Compound 4, half-maximal inhibitory concentration: > 50000 nM
Compound 4 was reported as a limit; the forecaster's own chance of this, stated with the estimate: 85%; the middle value is on the limit's open side.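

In this assay compound 4 gives > 50000 nM as a limit only. Its steps from compound 1, compound 2 and compound 3 cannot be read. The compounds shown leave open whether any aryl group on the aromatic nitrogen gives a measurable value in this assay at all.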